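The source may report more compounds than this note shows. Statements on the series, on what has been measured and on what is new or still open speak of the compounds shown alone.

Measured compounds in a functional assay on SH-SY5Y cells (Homo sapiens) for cytotoxicity, read by MTT assay, with stated times of 24 h and 4 h; a lower number here means that less compound is needed, a higher number that more compound is needed for the effect:
- compound 1, `COc1cc(CNC(=O)/C=C/c2ccccc2)ccc1OCc1nc(C)c(C)nc1C`: 7310 nM
- compound 2, `COc1cc(CNC(=O)/C=C/c2ccccc2O)ccc1OCc1nc(C)c(C)nc1C`: 5300 nM
- compound 3, `COc1ccc(/C=C/C(=O)NCc2ccc(OCc3nc(C)c(C)nc3C)c(OC)c2)cc1`: 5050 nM

Compound 3 gives the lowest of the three numbers in this assay, but its nearest neighbour compound 2 differs only by a 1.0-fold lower number from compound 2 to compound 3 (0.02 log units; within the scatter) and the furthest, compound 1, by a 1.4-fold lower number from compound 1 to compound 3 (0.16 log units; within the scatter); all three values sit within the scatter of one another, so no order among them can be read.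

Compound 4, `COc1cc(CNC(=O)/C=C/c2cccc(OC)c2OC)ccc1OCc1nc(C)c(C)nc1C`, is the next member. It differs from compound 3 by 2,3-dimethoxyphenyl in place of 4-methoxyphenyl on a double-bonded chain carbon bound to a double-bonded chain carbon.

Among the measured compounds shown here, the steps that bear on this change are those touching the same ring: adding a methoxy there, a 1.4-fold lower number from compound 1 to compound 3 (0.16 log units; within the scatter), adding a hydroxy there, a 1.4-fold lower number from compound 1 to compound 2 (0.14 log units; within the scatter), and exchanging one substituted phenyl for another, a 1.0-fold lower number from compound 2 to compound 3 (0.02 log units; within the scatter). Each of these stayed within the scatter. The expectation for compound 4 is therefore no step beyond the scatter, in either direction, from compound 3; the expected step is a 1.0-fold higher number from compound 3 to compound 4 (0.01 log units; within the scatter). Compound 4 is estimated at 5200 nM in this assay, with a range from 2600 nM to 10400 nM.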

Compound 4, half-maximal effective concentration: 7150 nM
For compound 4 the middle estimate is 1.4-fold (0.14 log units) below the measured one; measured number inside the range.
By their numbers in this assay, from the lowest: compounds 3, 2, 4 and 1 (each within the scatter of the next).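

Across the ring variants on the double-bonded chain carbon, this assay shows a 1.4-fold higher number from compound 3 to compound 4 (0.15 log units; within the scatter) and a 1.3-fold higher number from compound 2 to compound 4 (0.13 log units; within the scatter) and also a 1.0-fold lower number from compound 1 to compound 4 (0.01 log units; within the scatter) for the entry of 2,3-dimethoxyphenyl. The earlier compounds shown here carried no more than one substituent on this ring, whereas compound 4 carries two methoxy groups and still stays within the scatter of compounds 1, 2 and 3, so the four compounds allow no order among them. No supporting measurement is available to explain this outcome.

Going by these compounds, whether an amine or a carboxylic acid on this ring would give a step beyond the scatter remains open. Also open, on these data alone, is whether a longer chain in place of the ring would do so, or whether a change elsewhere in the shared core would.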